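This account rests on a few compounds, and the source may have more. Where it says the series, first, only, none or still open, it means among the compounds named here.

Measured compounds:
Compound 1, `CC(C)(C)[Si](C)(C)O[C@@H]1CCCO[C@@H]1/C=C/C(=O)OCc1ccccc1`: in a functional assay on A2780 cells (Homo sapiens) for antiproliferative activity, read by sulforhodamine B assay, with a stated time of 48 h (a lower number here means a stronger inhibitor of growth, a higher number a weaker inhibitor of growth), compound 1 gives 32000 nM.
Compound 2, `O=C(/C=C/[C@H]1OCCC[C@H]1O)OCc1ccccc1`: in this assay compound 2 gives > 100000 nM, which is a limit of the assay and not a number.
Compound 3, `CC(C)(C)[Si](C)(C)O[C@@H]1CCCO[C@@H]1CC(=O)OCc1ccccc1`: in this assay compound 3 gives 23000 nM.

Compound 1 and compound 2 differ by one change, (a hydrogen atom in place of a group of 7 heavy atoms (6 carbon, 1 silicon; no ring), on an oxygen on a saturated carbon). That change brings an at least 3.1-fold higher number from compound 1 to compound 2 (0.49 log units; beyond the scatter). The step can only be stated as a lower bound because compound 2 sits at the limit of > 100000 nM in this assay, at which 1 of the 3 values shown sits.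

Compound 3 has the lowest of the two plain numbers, and compound 1 stands nearest to it; the gap between them lies within the scatter, so no order between the two can be read from it. How the core of compound 3 differs from the core of compound 1 is not broken down here.

Compound 4, `O=C(C[C@H]1OCCC[C@H]1O)OCc1ccccc1`, has not yet been measured. For the measured compounds named here, it differs from compound 3 by a hydrogen atom in place of a group of 7 heavy atoms (6 carbon, 1 silicon; no ring), on an oxygen on a saturated carbon, which is the same change as the one from compound 1 to compound 2. The step from compound 3 to compound 4 is expected to be a 4.3-fold higher number from compound 3 to compound 4 (0.64 log units; beyond the scatter), set beside an at least 3.1-fold higher number from compound 1 to compound 2 (0.49 log units; beyond the scatter), and this expectation rests on that single measured step alone. In this assay compound 4 is estimated at 100000 nM, expected to fall between 40000 nM and 300000 nM, with a real chance that only a limit is reported.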

Compound 4, concentration for 50% growth inhibition: > 100000 nM
Compound 4: no number, only a limit; the forecaster's own chance of this, stated with the estimate: 60%; the middle value lies on the limit itself.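

In this assay, a hydrogen atom in place of the group of 7 heavy atoms (6 carbon, 1 silicon; no ring), on an oxygen on a saturated carbon, brings an at least 4.3-fold higher number from compound 3 to compound 4 (0.63 log units; beyond the scatter). The change therefore goes the same way on the two cores shown, and on both the step lies beyond the scatter: the same change on two cores in this assay, an at least 3.1-fold higher number (0.49 log units; beyond the scatter) from compound 1 to compound 2 and an at least 4.3-fold higher number (0.63 log units; beyond the scatter) from compound 3 to compound 4; the limit leaves it open whether they differ Compound 4 gives > 100000 nM, which is a limit of the assay and not a number, so the series shows the direction of the change but neither its full size on either core nor whether that size carries over unchanged: the limit of > 100000 nM in this assay, at which 2 of the 4 values shown sit.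

The compounds shown leave open whether another group on this oxygen, such as a methyl ether, an acetyl ester or a smaller silyl group, would stay close to the silylated compounds or fall away as the hydrogen does. They also leave open whether the same step would appear if an amide or a carboxylic acid stood in place of the benzyl ester, or on a core carrying a longer chain.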